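Aryl replacement on a shared ketone-oxazole core

The source may hold more compounds than are shown below. What is called first, only, known or untested is meant among the compounds shown, and "the series" means these compounds.

Three measured compounds share one core and differ only in the aromatic group attached to it. In an assay (Rattus norvegicus) for inhibition of Fatty-acid amide hydrolase 1 (Homo sapiens) (on this read-out lower numbers stand for stronger inhibition and higher numbers for weaker inhibition), compound 1 `NC(=O)c1cccc(-c2cnc(C(=O)CCCCCCc3ccccc3)o2)c1` gives 6 nM. Compound 2 `Nc1ccc(-c2cnc(C(=O)CCCCCCc3ccccc3)o2)cc1` gives 90 nM in this assay, and compound 3 `COc1ccnc(-c2cnc(C(=O)CCCCCCc3ccccc3)o2)c1` gives 0.8 nM. The steps are a 15-fold higher number from compound 1 to compound 2 (1.18 log units; beyond the scatter), a 7.5-fold lower number from compound 1 to compound 3 (0.88 log units; beyond the scatter) and a 110-fold lower number from compound 2 to compound 3 (2.05 log units; beyond the scatter). Compound 3 therefore stands lowest of the three, with both other compounds beyond the scatter above it.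

Compound 4 `O=C(CCCCCCc1ccccc1)c1ncc(-c2ncccn2)o1` has not been measured; it differs from compound 3 by pyrimidin-2-yl in place of 4-methoxypyridin-2-yl on an aromatic carbon. Going by the values given here, none of the measured steps exchanges one six-membered heteroaryl group for another; each of them swaps a benzene-based group, and together they cover a wide range of this assay. They show that this position moves the number strongly, but give no direct guide to this particular exchange. A moderate rise from compound 3 is expected, with the outcome of compound 4 estimated at 5 nM, between 1 nM and 30 nM. The expected step is a 6.3-fold higher number from compound 3 to compound 4 (0.80 log units; beyond the scatter).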

Compound 4, inhibition constant: 5.3 nM
Estimate against measurement, compound 4: 1.1-fold (0.03 log units) below, within the range that was stated.
By their numbers in this assay, from the lowest: compound 3; then compounds 4 and 1 (each within the scatter of the next); then compound 2.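

In this assay, going by these compounds alone, the step of a 6.6-fold higher number from compound 3 to compound 4 (0.82 log units; beyond the scatter) is the first exchange of one six-membered heteroaryl group for another, and it shows that this position still separates such groups: pyrimidin-2-yl does not hold the level of 4-methoxypyridin-2-yl. Against the benzene-based groups the result divides, with a 1.1-fold lower number from compound 1 to compound 4 (0.05 log units; within the scatter) lying within the scatter, so that pyrimidin-2-yl matches 3-carbamoylphenyl, while a 17-fold lower number from compound 2 to compound 4 (1.23 log units; beyond the scatter) leaves it well clear of 4-aminophenyl. Nothing available here gives a reason for any of these steps.

This exchange removes the methoxy group and adds a second ring nitrogen in one step, and the compounds shown do not tell which of the two goes with the rise. An unsubstituted pyridine ring or a pyrimidine ring carrying a methoxy group would separate these two changes.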